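The compounds below may be only part of what the source reports. "The series", "measured", "known", "first", "only" and "open" are said of these compounds alone.

Of the compounds shown here, three have been measured in an assay on HEK293 cells for binding affinity to Substance-K receptor (Rattus norvegicus), read by FRET, tested at 10 uM; on this read-out higher numbers stand for more inhibition at the one concentration tested (going by the name of the read-out) and lower numbers for less inhibition. Compound 1 `N#CCN(Cc1ccccc1)Cc1ccc2ccccc2n1` gives 0%, compound 2 `C#CCN(Cc1ccccc1)Cc1ccc2ccccc2c1` gives 0%, and compound 3 `CCCCCCCCCCCCCCCCOC(=O)CN(Cc1ccccc1)Cc1ccc2ccccc2c1` gives 0%. Compound 2 therefore stands level with compound 1 and compound 3 at the digits shown, and all three values lie within the scatter of one another, so no ordering among them can be read. Compound 4 `c1ccc(CN(Cc2ccc3ccccc3c2)c2cccnc2)cc1` has not yet been measured. It differs from compound 2 in one place: pyridin-3-yl in place of propargyl on an amine nitrogen. Within the data shown here, no step between measured compounds exists to guide an expectation, and every measured value sits at the same level. The step in this assay is therefore expected to be no change at the digits printed from compound 2 to compound 4 (within the scatter), none beyond the scatter. Compound 4 is estimated at 0%, with a range from -10% to 15%.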

Compound 4, a percentage reported as inhibition, at one concentration (the size of the read-out at that concentration, not a potency): 0%
Beside the measured number, compound 4's estimate shows no gap at the digits printed; low and high end bracket the measured number.
By their numbers in this assay, from the lowest: compounds 1, 2, 3 and 4 (each within the scatter of the next).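

In this assay, putting pyridin-3-yl in place of propargyl on an amine nitrogen gives no change at the digits printed from compound 2 to compound 4 (within the scatter). Among these compounds, this is the first step that can be read between compounds differing in one place, and it shows that an aromatic ring carrying a hydrogen-bond acceptor at this position, in place of a triple bond, leaves the reading unmoved. No evidence at hand bears on this result.

The compounds shown leave open whether a carboxylic acid or a primary amine on this nitrogen would give any inhibition. They also leave open whether any group at this position matters while the rest of the core stays unchanged.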